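Furanyl in place of chlorophenyl on a weakly active scaffold

The source may hold more compounds than are shown below. What is called first, only, known or untested is meant among the compounds shown, and "the series" means these compounds.

The three measured compounds share one core and were tested in a functional assay on A549 cells (Homo sapiens) for cytotoxicity, read by sulforhodamine B assay, with a stated time of 72 h; a higher number here means a weaker inhibitor, a lower number a stronger inhibitor. Compound 1 `Cc1c(-c2csc(/N=c3\sc(-c4ccccc4)nn3-c3ccccc3)n2)c(=O)n(-c2ccccc2)n1C` gives only a limit, > 100000 nM. Compound 2 `CCOC(=O)c1nn(-c2ccc(OC)cc2)/c(=N/c2nc(-c3c(C)n(C)n(-c4ccccc4)c3=O)cs2)s1` carries an ester and a methoxyphenyl on its outer ring and gives 13100 nM in this assay. Compound 3 `Cc1c(-c2csc(/N=C3\S/C(=C\c4ccc(Cl)cc4)C(=O)N3c3ccccc3)n2)c(=O)n(-c2ccccc2)n1C`, which bears a 4-chlorophenyl on a double-bonded chain carbon, again gives only a limit, > 100000 nM. Compound 3 therefore sits at the limit of > 100000 nM in this assay, at which 2 of the 3 values shown sit, so no number is known for it, and its step to compound 2 cannot be sized.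

Compound 4 `Cc1c(-c2csc(/N=C3\S/C(=C\c4ccco4)C(=O)N3c3ccccc3)n2)c(=O)n(-c2ccccc2)n1C` differs from compound 3 by furan-2-yl in place of 4-chlorophenyl on a double-bonded chain carbon bound to a double-bonded ring carbon. Among the measured compounds shown here, no measured pair shows what such an exchange does here. Given that compound 3 gives only the limit > 100000 nM, the step expected in this assay, a number no higher from compound 3 to compound 4 (the limit leaves the size open), is none beyond the scatter. For compound 4 the estimate is 100000 nM, within 30000 nM to 300000 nM, most likely reported again as a limit.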

Compound 4, half-maximal inhibitory concentration: 13700 nM
Compound 4: middle estimate off by 7.3-fold (0.86 log units), on the high side, outside the stated range (below it).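

In this assay the exchange of 4-chlorophenyl for furan-2-yl gives an at least 7.2-fold lower number from compound 3 to compound 4 (0.86 log units; beyond the scatter), so a single group on the double-bonded chain carbon bound to a double-bonded ring carbon can move the read-out beyond the scatter. The size of this step is only a bound, as compound 3 gives a limit and not a number: the limit of > 100000 nM in this assay, at which 2 of the 4 values shown sit. Among the compounds shown here, it is also the first step in this set that can be read at all, as the earlier compounds offered no pair differing in one place.

As far as these compounds go, it remains open whether the step belongs to the furan-2-yl ring itself or to the loss of the chlorine, which an unsubstituted phenyl or a thiophen-2-yl at this place would separate. From the compounds shown here alone, how far the true number of compound 3 lies past its limit, and so how large the step really is, also stays open.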